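Benzyl ether variation on the aryl oxygen, compound 3 to 4

The source may hold more compounds than are shown below. What is called first, only, known or untested is meant among the compounds shown, and "the series" means these compounds.

In a functional assay on HCT-116 cells (Homo sapiens) for antiproliferative activity, read by MTT assay, with a stated time of 24 h (a lower number here means a stronger inhibitor, a higher number a weaker inhibitor), compound 3 `COc1cc(OC)c(-c2coc3cc(OCc4ccc(F)cc4)ccc3c2=O)cc1OC` gives 950 nM, the lowest of the two numbers given. Compound 1 `C#CCOc1ccc2c(=O)c(-c3cc(OC)c(OC)cc3OC)coc2c1` gives 8050 nM in this assay. Compound 2 `COc1cc(OC)c(-c2coc3cc(OCC(=O)c4cccc(C(F)(F)F)c4)ccc3c2=O)cc1OC` reaches only a limit, > 10000 nM, in this assay. The group on this carbon moves the readout strongly where it has been measured: an 8.5-fold lower number from compound 1 to compound 3 (0.93 log units; beyond the scatter) and an at least 10-fold lower number from compound 2 to compound 3 (1.02 log units; beyond the scatter). Compound 4 `COc1cc(OC)c(-c2coc3cc(OCc4cccc(Cl)c4)ccc3c2=O)cc1OC` differs from compound 3 by 3-chlorophenyl in place of 4-fluorophenyl on a saturated chain carbon bound to an oxygen on an aromatic ring. No measured step exchanges one substituted phenyl for another at this place; the shown steps say only that the group here matters. A step within the scatter is expected, a 1.3-fold higher number from compound 3 to compound 4 (0.10 log units; within the scatter), with direction uncertain. Compound 4 is estimated at 1200 nM in this assay, within 400 nM to 3500 nM.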

Compound 4, half-maximal inhibitory concentration: 1330 nM
For compound 4 the middle estimate is 1.1-fold (0.04 log units) below the measured one; measured number inside the range.
By their numbers in this assay, from the lowest: compounds 3 and 4 (each within the scatter of the next); then compound 1. At a limit, above all of these: compound 2.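

Exchanging one substituted phenyl for another on this carbon leaves the readout in this assay within the scatter: a 1.4-fold higher number from compound 3 to compound 4 (0.15 log units; within the scatter). The gain from this kind of group is therefore not particular to 4-fluorophenyl, as 3-chlorophenyl also gives a 6.1-fold lower number from compound 1 to compound 4 (0.78 log units; beyond the scatter) and an at least 7.5-fold lower number from compound 2 to compound 4 (0.87 log units; beyond the scatter). The value of compound 2 is a limit, not a number: the limit of > 10000 nM in this assay, at which 1 of the 4 values shown sits.

As far as these compounds go, it remains open whether an unsubstituted phenyl, a pyridine or a longer chain ending in an amine would hold the readout at this level in this place.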